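The source may hold more compounds than are shown below. What is called first, only, known or untested is meant among the compounds shown, and "the series" means these compounds.

Compound 1 `Cc1nc(C(NC(=O)C(=O)Nc2ccc(F)cc2)C2CCCCN2)sc1CCO` is the only one of the three measured compounds to give a number in an ADME assay on MT2 cells (Homo sapiens) for cytotoxicity, read by XTT assay, with a stated time of 4 days (on this read-out lower numbers stand for higher toxicity in this test and higher numbers for lower toxicity in this test), where compound 1 gives 109000 nM. The two companions report limits of this assay rather than numbers. Compound 2 `Cc1nc(C(NC(=O)C(=O)Nc2ccc(Cl)cc2)C2CCCCN2)sc1CO` reaches only a limit in this assay, at > 108000 nM. Compound 3 `Cc1nc(C(NC(=O)C(=O)Nc2ccc(Cl)cc2)C2CCCNC2)sc1CCO` likewise reaches only a limit, at > 78500 nM. Because the limit of > 108000 nM in this assay, at which 1 of the 3 values shown sits, and the limit of > 78500 nM in this assay, at which 1 of the 3 values shown sits, sit close to the number for compound 1, all three compounds show low toxicity in this assay.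

Compound 4 `Cc1ccc(NC(=O)C(=O)NC(c2nc(C)c(CCO)s2)C2CCCCN2)cc1F` has not been measured. It differs from compound 1 in one place: 3-fluoro-4-methylphenyl in place of 4-fluorophenyl on an amide-type nitrogen. Within the data shown here, no step between measured compounds shows what such a change does in this assay. With nothing in the measured compounds pointing either way, the change is expected to leave the read-out where it stands, with a step from compound 1 to compound 4 of a 1.1-fold lower number from compound 1 to compound 4 (0.04 log units; within the scatter), within the usual scatter. Compound 4 is therefore estimated at 100000 nM, between 40000 nM and 220000 nM, and may well reach only a limit of this assay.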

Compound 4, half-maximal cytotoxic concentration: 85000 nM
For compound 4 the middle estimate is 1.2-fold (0.07 log units) above the measured one; the measured number falls inside the stated range.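

Putting 3-fluoro-4-methylphenyl in place of 4-fluorophenyl on the amide-type nitrogen gives a 1.3-fold lower number from compound 1 to compound 4 (0.11 log units; within the scatter) in this assay and so makes no real difference to the read-out. This is the first step shown at this place, and it shows that the phenyl ring here can carry a methyl group and a differently placed fluorine without the result leaving the usual scatter of the test. Nothing among the measurements shown offers a reason for the size of this step.

Among these compounds, the single step changes the methyl group and the fluorine together, so the part each plays on its own stays open. Also open, from the compounds shown here alone, is whether a different kind of group on this ring, such as a carboxylic acid or an amine, would leave the read-out just as unmoved.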